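A pair differing only in drawn configuration

The source may hold more compounds than are shown below. What is called first, only, known or untested is meant among the compounds shown, and "the series" means these compounds.

In a physicochemical assay for lipophilicity (on this read-out higher numbers stand for higher lipophilicity and lower numbers for lower lipophilicity), compound 1 `CCNC(=O)Nc1ccc(-c2nc(CS(C)(=O)=O)cc([C@]34CCOC[C@H]3C4)n2)cc1` gives 3.6, compound 2 `CCNC(=O)Nc1ccc(-c2nccc([C@]34CCOC[C@H]3C4)n2)cc1` gives 3.9 and compound 3 `CCNC(=O)Nc1ccc(-c2nc(C(C)(C)S(C)(=O)=O)cc([C@]34CCOC[C@H]3C4)n2)cc1` gives 4.7. Hydrogen in place of (methylsulfonyl)methyl on an aromatic carbon gives a number 0.30 log units higher from compound 1 to compound 2 (within the scatter), so these two values cannot be separated. Compound 2 therefore stands level with compound 1, and compound 3 stands clear of both. 1-Methyl-1-(methylsulfonyl)ethyl in place of hydrogen gives a number 0.80 log units higher from compound 2 to compound 3 (beyond the scatter), and the same group in place of (methylsulfonyl)methyl gives a number 1.10 log units higher from compound 1 to compound 3 (beyond the scatter).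

The next structure is compound 4 `CCNC(=O)Nc1ccc(-c2nccc(C34CCOCC3C4)n2)cc1`, which has the same atoms and bonds as compound 2: the two compounds have the same atoms and bonds; at least one stereo element is drawn with a configuration in one of them and without one in the other: 2 of 2 stereo elements differ; a stereocentre at a saturated ring carbon is drawn R in compound 2 and without a configuration in compound 4; a stereocentre at a saturated ring carbon is drawn S in compound 2 and without a configuration in compound 4. All three measured steps exchange a group on an aromatic carbon, and none alters a drawn configuration. For the measured compounds named here, their sizes therefore say little about this change, and the series holds no measured pair of this kind. With no atom or bond changed from compound 2 at 3.9, no step beyond the scatter is expected in this assay, and no direction is favoured. The estimated step is no change at the digits printed from compound 2 to compound 4 (within the scatter). For compound 4 the estimated value is 3.9, with an expected range from 3.6 to 4.2.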

Compound 4, partition coefficient: 4
The estimate for compound 4 lay 0.10 log units below the measured number; measured number inside the range.
By their numbers in this assay, from the lowest: compounds 1, 2 and 4 (each within the scatter of the next, the first and the last beyond it); then compound 3.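

In this assay the series now holds a step with no atom or bond changed, a number 0.10 log units higher from compound 2 to compound 4 (within the scatter), so the two values cannot be separated. The earlier steps shown here all exchange a group on an aromatic carbon and say nothing about configuration, whereas this pair isolates a single distinction at the two saturated ring carbons: the fact that one of compounds 2 and 4 is drawn with a defined configuration and the other without, at the place where they differ At this position, a configuration drawn at both stereocentres and one left undrawn therefore give readings that cannot be told apart in this assay, which is a statement about this pair only and does not extend to compounds 1 and 3.

As far as these compounds go, an undrawn configuration does not show whether compound 4 is a single form or a mixture, so how the configuration opposite to that drawn in compound 2 would read in this assay remains open, and the pair does not establish that configuration is without consequence here. Also open, from the compounds shown here alone, is how a group such as an amine or a carboxylic acid, in place of hydrogen on the same aromatic carbon, would read against compound 2.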